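Fluoro in place of hydrogen on the phenyl of compound 1

The source may hold more compounds than are shown below. What is called first, only, known or untested is meant among the compounds shown, and "the series" means these compounds.

Measured so far in a functional assay on CHO cells for agonist activity at Free fatty acid receptor 1 (Homo sapiens), read by FLIPR and calcium flux, tested at 100 nM; a lower number here means a weaker effect, a higher number a stronger effect of the compound at the concentration tested:
compound 1, `Cc1nc(-c2ccccc2)sc1COc1ccc2c(c1)OCC2CC(=O)O`: 54.8%
compound 2, `Cc1cccc(-c2nc(C)c(COc3ccc4c(c3)OCC4CC(=O)O)s2)c1`: 47.2%
compound 3, `Cc1nc(-c2ccccc2Cl)sc1COc1ccc2c(c1)OCC2CC(=O)O`: 12.4%

Compound 1 gives the highest of the three numbers. Compound 2 lies close to it, the step of a number 7.6 percentage points lower from compound 1 to compound 2 (within the scatter) staying within the scatter, so the two cannot be ordered. Compound 3 falls well below, the step of a number 42.4 percentage points lower from compound 1 to compound 3 (beyond the scatter) being large and beyond the scatter; the same holds for a number 34.8 percentage points lower from compound 2 to compound 3 (beyond the scatter).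

Compound 4, `Cc1nc(-c2ccccc2F)sc1COc1ccc2c(c1)OCC2CC(=O)O`, differs from compound 1 by fluoro in place of hydrogen on an aromatic carbon. Going by the values given here, the step that bears on it is the one from compound 1 to compound 3, where chloro enters at the same place and the activity drops sharply. Fluoro is a smaller group entering at that place, so a drop is expected again, most likely beyond the scatter but not as deep as that seen with chloro; there is no measured fluoro analogue to settle how much smaller.

The estimated step is a number 24.8 percentage points lower from compound 1 to compound 4 (beyond the scatter). Compound 4 is therefore expected to give 30%, with a range from 10% to 50%.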

Compound 4, a percentage reported as activity, at one concentration (the size of the read-out at that concentration, not a potency): 25.8%
Compound 4: middle estimate off by 4.2 percentage points, on the high side, and the stated range covers the measured number.
By their numbers in this assay, from the lowest: compound 3; then compound 4; then compounds 2 and 1 (each within the scatter of the next).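

In this assay, even the single fluorine atom at this place, ortho to a large group, costs activity, with a number 29 percentage points lower from compound 1 to compound 4 (beyond the scatter), so the loss at this place is not confined to chloro. The choice of halogen still matters, as shown by a number 13.4 percentage points higher from compound 3 to compound 4 (beyond the scatter), and the phenyl change can also be read against the methyl compound in a number 21.4 percentage points lower from compound 2 to compound 4 (beyond the scatter), a comparison in which both the group and its place on the ring differ. Nothing available gives a reason for the loss of activity or for the gap between fluoro and chloro.

Open, on these data alone, is whether methyl, methoxy or hydroxyl at this same place would also lower the read-out, and whether any group there can match the unsubstituted phenyl of compound 1. Also open, as far as these compounds go, is whether fluoro at another place on the phenyl behaves as it does here, and whether these differences at a single concentration reflect potency, maximal effect or both.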